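From Cyclohexyl to 3-Methylphenyl on the Amide-Type Nitrogen

The source may report more compounds than this note shows. Statements on the series, on what has been measured and on what is new or still open speak of the compounds shown alone.

Of the compounds shown here, three built on one shared core have been tested in a functional assay on HepG2 cells (Homo sapiens) for antiproliferative activity, read by MTT assay, with a stated time of 48 h; a lower number here means a stronger inhibitor, a higher number a weaker inhibitor. Compound 1 `O=C(Nc1cccc(CNc2nccnc2Cl)c1)NC1CCCCC1` carries a cyclohexyl on an amide-type nitrogen. In this assay compound 1 reaches only a limit, > 40000 nM, so no number is known for it (the limit of > 40000 nM in this assay, at which 1 of the 3 values shown sits). Compound 2 `O=C(Nc1cccc(CNc2nccnc2Cl)c1)NC1CCCC1` carries a cyclopentyl in that place and gives 18400 nM. Compound 3 `O=C(Nc1cccc(CNc2nccnc2Cl)c1)Nc1ccc(Cl)cc1Cl` carries a 2,4-dichlorophenyl there and gives 7230 nM. The measured steps run an at least 2.1-fold lower number from compound 1 to compound 2 (0.33 log units; beyond the scatter), an at least 5.5-fold lower number from compound 1 to compound 3 (0.74 log units; beyond the scatter) and a 2.5-fold lower number from compound 2 to compound 3 (0.41 log units; beyond the scatter).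

Compound 4 `Cc1cccc(NC(=O)Nc2cccc(CNc3nccnc3Cl)c2)c1` differs from compound 1 in one place: 3-methylphenyl in place of cyclohexyl on an amide-type nitrogen. Among the compounds with values here, the step that bears most on it is the one from compound 1 to compound 3, where an aromatic ring also replaced the cyclohexyl, and the step from compound 1 to compound 2 points the same way. A lower number is therefore expected for compound 4, though a 3-methylphenyl is not a 2,4-dichlorophenyl, so the size is uncertain. Compound 4 is estimated to give 12000 nM, between 4000 nM and 40000 nM, which is expected to mean an at least 3.3-fold lower number from compound 1 to compound 4 (0.52 log units; beyond the scatter).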

Compound 4, half-maximal inhibitory concentration: 11200 nM
Compound 4: middle estimate off by 1.1-fold (0.03 log units), on the high side; the measured number falls inside the stated range.
By their numbers in this assay, from the lowest: compounds 3, 4 and 2 (each within the scatter of the next, the first and the last beyond it). At a limit, above all of these: compound 1.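

A second aromatic ring on the amide-type nitrogen also gives a step beyond the scatter in this assay, an at least 3.5-fold lower number from compound 1 to compound 4 (0.55 log units; beyond the scatter), and this size is only a lower bound, since compound 1 has a limit and not a number: the limit of > 40000 nM in this assay, at which 1 of the 4 values shown sits.

Replacing the 2,4-dichlorophenyl with 3-methylphenyl gives a 1.5-fold higher number from compound 3 to compound 4 (0.19 log units; within the scatter), so these two ring patterns cannot be told apart here. Replacing cyclopentyl with 3-methylphenyl gives a 1.6-fold lower number from compound 2 to compound 4 (0.22 log units; within the scatter), so compound 4 cannot be ranked against compound 2 either, even though compound 2 and compound 3 differ beyond the scatter.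

The shown compounds leave open how an unsubstituted phenyl ring would compare with these rings. They also leave open whether a methoxy group or a carboxylic acid on the ring would change the result.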